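This account rests on a few compounds, and the source may have more. Where it says the series, first, only, none or still open, it means among the compounds named here.

Compound 2, `C=C(Br)C(=O)Nc1cccc(-c2cn3nc(-c4cccc(OC)c4)sc3n2)c1`, carries a (1-bromoethenyl)carbonyl group on the ring nitrogen; in a functional assay on HeLa cells (Homo sapiens) for inhibition, read by cell counting, with a stated time of 4 days (a higher number here means a weaker inhibitor, a lower number a stronger inhibitor), compound 2 gives 1100 nM. Compound 1, `COc1ccc(-c2nn3cc(-c4cccc(N)c4)nc3s2)cc1OC`, has a free amino group and two methoxy groups on its other aryl ring, and in this assay compound 1 gives 26000 nM. Among the compounds with values here, compound 2 stands lowest of the two numbers, and compound 1, its only neighbour, sits far higher, a gap well beyond the scatter. Compound 3, `COc1cccc(-c2nn3cc(-c4cccc(N)c4)nc3s2)c1`, has not yet been measured. It differs from compound 2 in one place: hydrogen in place of (1-bromoethenyl)carbonyl on a nitrogen on an aromatic ring. Within the data shown here, the acrylamide is gone, leaving the bare amino group, and the only measured amino compound, compound 1, sits at the weak end of the range. The step from compound 2 to compound 3 is therefore expected to be a large loss of potency, an 18-fold higher number from compound 2 to compound 3 (1.26 log units; beyond the scatter), rather than one within the scatter. For compound 3 in this assay the estimate is 20000 nM, with a likely range from 5000 nM to 80000 nM, resting on the number that compound 1 shows.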

Compound 3, half-maximal inhibitory concentration: 230000 nM
Beside the measured number, compound 3's estimate is 12-fold (1.06 log units) below it; measured number outside the range, above it.
By their numbers in this assay, from the lowest: compound 2; then compound 1; then compound 3.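

In this assay, within the data shown here, the step of a 210-fold higher number from compound 2 to compound 3 (2.32 log units; beyond the scatter) gives the first direct reading of this change, on a nitrogen on an aromatic ring: with the rest of the structure held constant, replacing (1-bromoethenyl)carbonyl with hydrogen makes a large difference, one that compound 1 could not show because it differs from compound 2 in more than one place. The step of an 8.8-fold higher number from compound 1 to compound 3 (0.95 log units; beyond the scatter) is modest beside it but still beyond the scatter, showing that among the compounds with the free amino group, hydrogen in place of methoxy on an aromatic carbon also raises the number. No measurement here explains why either change moves the number as it does.

Going by these compounds, it remains open whether the (1-bromoethenyl)carbonyl effect belongs to the bromine, to the double bond or to the amide carbonyl, which a plain acetyl group or an unbrominated acryloyl group on the same nitrogen would help to separate. On these data alone, it also remains open whether a second methoxy group would lower the number as far when the amino group carries (1-bromoethenyl)carbonyl.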